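The compounds below may be only part of what the source reports. "The series", "measured", "known", "first", "only" and "open" are said of these compounds alone.

Measured in a functional assay on HCT-116 cells (Homo sapiens) for inhibition, read by sulforhodamine B assay, with a stated time of 72 h; on this read-out lower numbers stand for stronger inhibition and higher numbers for weaker inhibition:
Compound 1 `CC(C)Cc1ccc(C(C)c2n[nH]c(=S)n2N)cc1`: 27400 nM
Compound 2 `CC(C)Cc1ccc(C(C)c2nnc3n2N=C(c2ccc(Cl)cc2Cl)CS3)cc1`: 11100 nM

Compound 2, at 11100 nM, holds the lower of the two numbers, and compound 1, at 27400 nM, lies higher by more than the usual scatter. Both numbers are modest, and the two compounds differ in more than one place, so neither pair gives a direct guide to substitution on the aromatic ring.

Compound 3 `CC(C)Cc1ccc(C(C)c2nnc3n2N=C(c2ccc(F)cc2)CS3)cc1` has 4-fluorophenyl in place of 2,4-dichlorophenyl on a carbon with a double bond to nitrogen. Going by the values given here, no measured pair isolates this exchange, so the expectation is loose. The expected size of the step of a 1.3-fold higher number from compound 2 to compound 3 (0.10 log units; within the scatter) is small, slightly toward a higher number in this assay, and probably within the scatter. For compound 3 the estimated value is 14000 nM, with an expected range of 5000 nM to 40000 nM.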

Compound 3, half-maximal inhibitory concentration: 12400 nM
Compound 3: middle estimate off by 1.1-fold (0.05 log units), on the high side; the measured number falls inside the stated range.
By their numbers in this assay, from the lowest: compounds 2 and 3 (each within the scatter of the next); then compound 1.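

In this assay, going by these compounds alone, the exchange of 2,4-dichlorophenyl for 4-fluorophenyl on the carbon with a double bond to nitrogen gives a 1.1-fold higher number from compound 2 to compound 3 (0.05 log units; within the scatter) and is the first change that can be read at a single place. At this position, in this one pair, the two halogen-bearing phenyl groups cannot be told apart, so the chlorine substituents of compound 2 are not required to keep its number, and one pair supports no wider rule. Nothing measured here bears on why the two groups read alike.

Still open, as far as these compounds go, is whether any group at this position moves the number beyond the scatter, for example an unsubstituted phenyl, a phenyl carrying an amine or a carboxylic acid, or a small alkyl such as methyl. From the compounds shown here alone, the effect of changes elsewhere on the shared core also remains unknown.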